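Replacing a Chain-End Methyl with Hydroxy: Cytotoxicity Outlook

The compounds below may be only part of what the source reports. "The series", "measured", "known", "first", "only" and "open" are said of these compounds alone.

Compound 1 `CCCCCNc1cc(Oc2c(OC)cc3cc(C#N)ccc3c2OC)nc(Nc2ccc(C#N)cc2)n1` was tested in an ADME assay on MT4 cells (Homo sapiens) for cytotoxicity, read by MTT assay, with a stated time of 5 days; on this read-out lower numbers stand for higher toxicity in this test and higher numbers for lower toxicity in this test. In this assay compound 1 gives > 125000 nM, which is a limit of the assay rather than a measured number. Compound 2 `COc1cc2cc(C#N)ccc2c(OC)c1Oc1cc(NC2CC2)nc(Nc2ccc(C#N)cc2)n1` gives > 125000 nM, likewise a limit. Compound 3 `COc1cc2cc(C#N)ccc2c(OC)c1Oc1cc(NCC2CCOC2)nc(Nc2ccc(C#N)cc2)n1` gives > 125000 nM, again a limit. Because of the limit of > 125000 nM in this assay, at which 3 of the 3 values shown sit, none of the steps among these three compounds can be sized: the step that the two limits leave unreadable from compound 1 to compound 2, the step that the two limits leave unreadable from compound 1 to compound 3 and the step that the two limits leave unreadable from compound 2 to compound 3 all remain unreadable, so compound 1 stands simply at the limit alongside the other two.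

Compound 4 `COc1cc2cc(C#N)ccc2c(OC)c1Oc1cc(NCCCCO)nc(Nc2ccc(C#N)cc2)n1` has not yet been measured in this assay. It differs from compound 1 by hydroxy in place of methyl on a saturated chain carbon, four bonds along the chain from a nitrogen on an aromatic ring. Within the data shown here, no measured step touches this kind of change, and every measured compound sits at the limit, so no direction or size beyond the scatter can be drawn from them. Compound 4 is therefore expected to give 125000 nM, with an estimated range from 60000 nM to 300000 nM. The step from compound 1 is expected to be a number no higher from compound 1 to compound 4 (the limit leaves the size open).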

Compound 4, half-maximal cytotoxic concentration: 39100 nM
Compound 4: the middle estimate sits 3.2-fold (0.50 log units) above what was measured; the measured number lies below the stated range.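

In this assay, compound 4 is the first compound shown with a measured number rather than a limit, and it shows that this place on the chain can affect the read-out: hydroxy in place of methyl gives an at least 3.1-fold lower number from compound 1 to compound 4 (0.50 log units; beyond the scatter). Compound 4 also stands apart from the other two side chains, with an at least 3.1-fold lower number from compound 3 to compound 4 (0.50 log units; beyond the scatter) and an at least 3.1-fold lower number from compound 2 to compound 4 (0.50 log units; beyond the scatter), so 4-hydroxybutyl goes with higher toxicity in this test than pentyl, cyclopropyl or (oxolan-3-yl)methyl. The full size of these steps stays open and the steps among compound 1, compound 2 and compound 3 cannot be read, because of this: the limit of > 125000 nM in this assay, at which 3 of the 4 values shown sit.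

From the compounds shown here alone, whether an amine or a carboxylic acid at the same place would give a similar number remains open. So does whether a longer chain ending in hydroxy would shift the number further.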